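A few compounds are considered here, and "the series" means these few. Any claim that something is new, unique, unknown or untested is made for them only; others in the source may bear on it.

In a functional assay on HepG2 cells (Homo sapiens) for antiproliferative activity, read by MTT assay, with a stated time of 48 h (a lower number here means a stronger inhibitor, a higher number a weaker inhibitor), compound 1 (`COc1ccc(/C=C/c2cc(OC)cc(OC)c2/C=C/C(=O)c2ccc(Cl)c(Cl)c2)cc1`) gives 10.8 ug/mL and compound 2 (`COc1ccc(/C=C/c2cc(OC)cc(OC)c2/C=C/C(=O)c2cccc(OC)c2)cc1`) gives 11.6 ug/mL while compound 3 (`COc1ccc(/C=C/c2cc(OC)cc(OC)c2/C=C/C(=O)c2ccc(Br)cc2)cc1`) gives 12.9 ug/mL and so stands level with both, within the scatter. Compound 4 (`COc1ccc(/C=C/c2cc(OC)cc(OC)c2/C=C/C(=O)c2ccc(F)cc2)cc1`) keeps the shared core of compound 3 and differs only in having fluoro in place of bromo on an aromatic carbon, para to a large group (fluoro in place of bromo on an aromatic carbon). The closest evidence comes from exchanges of the group on a carbonyl carbon. These gave a 1.2-fold higher number from compound 1 to compound 3 (0.08 log units; within the scatter) and a 1.1-fold higher number from compound 2 to compound 3 (0.05 log units; within the scatter) as well as a 1.1-fold higher number from compound 1 to compound 2 (0.03 log units; within the scatter) and each of them lies within the scatter. Among the compounds with values here, no measured step places fluoro where bromo stood, so the expectation rests on these three neighbours alone. Expected in this assay is a 1.0-fold lower number from compound 3 to compound 4 (0.01 log units; within the scatter) as the estimated step, with nothing beyond the scatter. For compound 4 the estimated value is 12.5 ug/mL (expected range 7 ug/mL to 22 ug/mL).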

Compound 4, half-maximal inhibitory concentration: 12.2 ug/mL
Beside the measured number, compound 4's estimate is 1.0-fold (0.01 log units) above it; measured number inside the range.
By their numbers in this assay, from the lowest: compounds 1, 2, 4 and 3 (each within the scatter of the next).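

Within the data shown here, with fluoro in place of bromo on an aromatic carbon, para to a large group, the halogen itself is exchanged directly for the first time, and in this assay the step stays small (a 1.1-fold lower number from compound 3 to compound 4 (0.02 log units; within the scatter)). The 4-fluorophenyl group also reads level with the other groups on the carbonyl carbon (a 1.1-fold higher number from compound 2 to compound 4 (0.02 log units; within the scatter); a 1.1-fold higher number from compound 1 to compound 4 (0.05 log units; within the scatter)), so all four groups shown there fall within the scatter of one another. No evidence is available that accounts for this flat result.

The compounds shown leave open whether a group of another kind at this position, such as an amine or a carboxylic acid, would shift the number beyond the scatter. On these data alone, all four also share one core, so the effect of changing the core remains open.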